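Fluorine to chlorine on the anilino ring of an acrylamide series

A few compounds are considered here, and "the series" means these few. Any claim that something is new, unique, unknown or untested is made for them only; others in the source may bear on it.

Two analogues of the shared core carry an acrylamide and a thioacetamide bridge to a fluoroanilino group. Compound 1 is `C=CC(=O)Nc1cccc(NC(=O)CSc2nc(Nc3ccccc3F)c3ccccc3n2)c1` and compound 2 is `C=CC(=O)Nc1cccc(NC(=O)CSc2nc(Nc3cccc(F)c3)c3ccccc3n2)c1`. In a functional assay on PC-3 cells (Homo sapiens) for inhibition, read by MTT assay, with a stated time of 72 h (a lower number here means a stronger inhibitor, a higher number a weaker inhibitor), compound 1 gives 9340 nM, and compound 2 gives 5370 nM. For the measured compounds named here, the only change between them, 3-fluorophenyl in place of 2-fluorophenyl on the nitrogen, reads as a 1.7-fold lower number from compound 1 to compound 2 (0.24 log units; within the scatter), so the two numbers are not separated beyond the scatter, and compound 2 cannot be called stronger than compound 1.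

The next compound, compound 3, is `C=CC(=O)Nc1cccc(NC(=O)CSc2nc(Nc3cccc(Cl)c3)c3ccccc3n2)c1`. It differs from compound 2 by chloro in place of fluoro on an aromatic carbon; the same difference read one bond further out is 3-fluorophenyl to 3-chlorophenyl. Going by the values given here, no measured step exchanges one halogen for another; the single step seen, from compound 1 to compound 2, moved the halogen around the ring and stayed within the scatter. Nothing measured therefore points to a change beyond the scatter in this assay for compound 3. Compound 3 is expected to give about 5000 nM, with a range of 2000 nM to 12000 nM. This estimate means a step of a 1.1-fold lower number from compound 2 to compound 3 (0.03 log units; within the scatter) from compound 2 to compound 3.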

Compound 3, half-maximal inhibitory concentration: 12300 nM
Compound 3: the middle estimate sits 2.5-fold (0.39 log units) below what was measured; the measured number lies above the stated range.
By their numbers in this assay, from the lowest: compounds 2, 1 and 3 (each within the scatter of the next, the first and the last beyond it).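

In this assay, for the compounds shown here, the exchange of halogen from 3-fluorophenyl to 3-chlorophenyl gives a 2.3-fold higher number from compound 2 to compound 3 (0.36 log units; beyond the scatter) and so becomes the first step beyond the scatter, though a modest one, showing that the number at this place on the ring can respond to which halogen is carried and not only to where a halogen sits. The comparison with the 2-fluorophenyl compound gives a 1.3-fold higher number from compound 1 to compound 3 (0.12 log units; within the scatter) and stays within the scatter, so the 3-chlorophenyl compound cannot be ordered against compound 1, and only compound 2 is separated from compound 3. Nothing available bears on why fluoro and chloro differ here.

Open, as far as these compounds go, is whether bromo, methyl, methoxy or an amine at the same place would extend this step, reverse it or leave the number within the scatter, since a single exchange of fluoro for chloro fixes no trend. Also open, from the compounds shown here alone, is whether chloro at the place held by fluorine in compound 1 would behave as it does in compound 3, and whether the step from fluoro to chloro recurs with a different group in place of the acrylamide.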